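Amino in Place of Hydroxy on Two Related Cores

The source may hold more compounds than are shown below. What is called first, only, known or untested is meant among the compounds shown, and "the series" means these compounds.

Measured compounds:
- compound 1, `Oc1ccc(-c2cccc(O)c2)cc1`: 3.4 ug/mL in a functional assay on HT-29 cells (Homo sapiens) for cytotoxicity, read by MTT assay, with a stated time of 3 days; on this read-out higher numbers stand for weaker inhibition and lower numbers for stronger inhibition
- compound 2, `Nc1cccc(-c2ccc(O)cc2)c1`: 5.4 ug/mL
- compound 3, `COc1ccc(-c2cccc(O)c2)cc1OC`: 29 ug/mL

Compound 1 and compound 2 differ only by amino in place of hydroxy on an aromatic carbon, and this change gave a 1.6-fold higher number from compound 1 to compound 2 (0.20 log units; within the scatter). Compound 3 stands highest of the three numbers; against compound 2 its number is higher beyond the scatter, and against compound 1 higher still. How the core of compound 3 differs from the core of compound 1 is not broken down here.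

Compound 4, `COc1ccc(-c2cccc(N)c2)cc1OC`, is not yet measured and differs from compound 3 by amino in place of hydroxy on an aromatic carbon. The surroundings of the place are not described word for word alike: in compound 1 the change sits meta to a group of 7 heavy atoms, in compound 3 meta to a large group, so the two are the same kind of change rather than the same. In this assay the step from compound 3 to compound 4 is expected to be a 1.4-fold higher number from compound 3 to compound 4 (0.16 log units; within the scatter), resting on the earlier 1.6-fold higher number from compound 1 to compound 2 (0.20 log units; within the scatter). Compound 4 is therefore estimated at 42 ug/mL, expected between 15 ug/mL and 120 ug/mL.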

Compound 4, half-maximal inhibitory concentration: 4 ug/mL
Beside the measured number, compound 4's estimate is 11-fold (1.02 log units) above it; the measured number lies below the stated range.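

In this assay, amino in place of hydroxy on an aromatic carbon gave a 7.3-fold lower number from compound 3 to compound 4 (0.86 log units; beyond the scatter), and this step does not match the one seen earlier on the other core: the same change on two cores in this assay, a 1.6-fold higher number (0.20 log units; within the scatter) from compound 1 to compound 2 and a 7.3-fold lower number (0.86 log units; beyond the scatter) from compound 3 to compound 4, 12-fold (1.06 log units) apart, beyond the scatter of two such steps.

The same change therefore cannot be carried from the core of compound 1 to the core of compound 3 in this series with its size kept, and the step on one core gave no safe reading of the step on the other. Within the data shown here, with only two pairs, this shows that the outcome of the change depends on the core it sits on, but it does not show which difference between the cores is responsible, nor how the change would behave on any further core.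

What the compounds shown leave open is whether other groups on the same aromatic carbon of the core of compound 3, such as a carboxylic acid or a nitrile, would also give a lower number than hydroxy. Also open, on these data alone, is whether a core carrying a single methoxy group would follow compound 1 and compound 2 or compound 3 and compound 4.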